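Exchanging the Aryl on the Ring Nitrogen of Compound 1

The source may hold more compounds than are shown below. What is called first, only, known or untested is meant among the compounds shown, and "the series" means these compounds.

Compound 1 `Oc1cc(C(F)(F)F)ccc1-c1nc(-c2ccccc2O)n(-c2ccc(F)cc2)n1` was tested in a functional assay on PC-12 cells (Rattus norvegicus) for cytotoxicity, read by MTT assay, with stated times of 2 h and 24 h, tested at 1 uM (a higher number here means a stronger effect of the compound at the concentration tested, a lower number a weaker effect), where compound 1 gives 67.2%. Among the three compounds with numbers, compound 1 stands second highest, yet all three sit within the scatter of one another. Its nearest neighbour, compound 2 `N#Cc1ccc(-n2nc(-c3ccc(C(F)(F)F)cc3O)nc2-c2ccccc2O)cc1`, gives 66.6%, and the furthest, compound 3 `Oc1cc(C(F)(F)F)ccc1-c1nc(-c2ccccc2O)n(-c2cccc(C(F)(F)F)c2)n1`, gives 71.5%. The measured steps are all small: a number 0.6 percentage points lower from compound 1 to compound 2 (within the scatter), a number 4.3 percentage points higher from compound 1 to compound 3 (within the scatter) and a number 4.9 percentage points higher from compound 2 to compound 3 (within the scatter).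

Compound 4 `Oc1cc(C(F)(F)F)ccc1-c1nc(-c2ccccc2O)n(-c2ccc(Cl)cc2Cl)n1` has not yet been measured. It differs from compound 1 in one place: 2,4-dichlorophenyl in place of 4-fluorophenyl on an aromatic nitrogen. Among the compounds with values here, the steps that bear on this exchange are the two that also replace the aryl group on the aromatic nitrogen, namely a number 4.3 percentage points higher from compound 1 to compound 3 (within the scatter) and a number 4.9 percentage points higher from compound 2 to compound 3 (within the scatter); both stayed within the scatter. With only these to go on, no step beyond the scatter is expected for the dichlorophenyl group either, and the expected step is a number 0.8 percentage points higher from compound 1 to compound 4 (within the scatter). Compound 4 is therefore estimated to give 68% in this assay, with a range from 58% to 78%.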

Compound 4, a percentage reported as activity, at one concentration (the size of the read-out at that concentration, not a potency): 69%
The estimate for compound 4 lay 1 percentage points below the measured number, and the stated range covers the measured number.
By their numbers in this assay, from the lowest: compounds 2, 1, 4 and 3 (each within the scatter of the next).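

In this assay, within the data shown here, the aryl on the aromatic nitrogen now carries two chlorine atoms, where the earlier compounds each carried a single substituent on that phenyl, and this exchange gives a number 1.8 percentage points higher from compound 1 to compound 4 (within the scatter) and a number 2.4 percentage points higher from compound 2 to compound 4 (within the scatter) as well as a number 2.5 percentage points lower from compound 3 to compound 4 (within the scatter) in the same series. All four aryl groups seen at this position, 4-fluorophenyl, 4-cyanophenyl, 3-(trifluoromethyl)phenyl and 2,4-dichlorophenyl, therefore lie within the scatter of one another, and the second substituent, with one heavy atom more in the group than 4-fluorophenyl, opens no gap in this small set. Nothing measured here accounts for this outcome or links it to any property of the groups.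

The compounds shown leave open whether an aryl bearing an amine or a carboxylic acid, or a longer alkyl chain in place of the aryl on the nitrogen, would step beyond the scatter in this assay. All four numbers also come from a single concentration, so they give the size of the read-out there and say nothing about potency at this position.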